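The source may hold more compounds than are shown below. What is called first, only, known or untested is meant among the compounds shown, and "the series" means these compounds.

Measured in a functional assay on A498 cells (Homo sapiens) for cytotoxicity; a higher number here means a weaker inhibitor of growth, a lower number a stronger inhibitor of growth:
- compound 1 `CSc1ccc(C2=C(c3ccc(F)c(C)c3)C(=O)N3CCCC3C2)cc1`: 300 nM
- compound 2 `CSc1ccc(C2=C(c3ccc(OCC4CO4)cc3)C(=O)N3CCCC3C2)cc1`: 500 nM

Compound 2 at 500 nM stands within the scatter of compound 1 at 300 nM. Compound 3 `CSc1ccc(C2=C(c3ccc(Br)cc3)C(=O)N3CCCC3C2)cc1` differs from compound 2 as follows: bromo in place of (oxiran-2-yl)methoxy on an aromatic carbon. The change is bromo in place of (oxiran-2-yl)methoxy on an aromatic carbon, para to a large group. Within the data shown here, no measured pair isolates this change, so the expectation rests only on those two close values. In this assay, no shift beyond the scatter is expected, and the estimated step is a 1.7-fold lower number from compound 2 to compound 3 (0.22 log units; within the scatter). The estimate for compound 3 is 300 nM, with an expected range of 100 nM to 900 nM.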

Compound 3, concentration for 50% growth inhibition: 7000 nM
Beside the measured number, compound 3's estimate is 23-fold (1.37 log units) below it; the whole stated range lies below it.
By their numbers in this assay, from the lowest: compounds 1 and 2 (each within the scatter of the next); then compound 3.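

Bromo in place of (oxiran-2-yl)methoxy gives a 14-fold higher number from compound 2 to compound 3 (1.15 log units; beyond the scatter) in this assay, so the group on this aromatic carbon, para to a large group, matters in a way the two close earlier values did not reveal. The 4-bromophenyl in place of 4-fluoro-3-methylphenyl likewise gives a 23-fold higher number from compound 1 to compound 3 (1.37 log units; beyond the scatter) in the same assay, so the two dissimilar groups of compound 1 and compound 2 share a level that compound 3 does not reach. Nothing available accounts for this drop. Open, on these data alone, is whether the ring of the (oxiran-2-yl)methoxy group is needed or the ether oxygen alone suffices. A plain methoxy or a 2-hydroxyethoxy group at this carbon would separate the two.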